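A few compounds are considered here, and "the series" means these few. Any claim that something is new, unique, unknown or untested is made for them only; others in the source may bear on it.

The measured compounds:
Compound 1, `O=C(O)/C=C/c1cc(O)c(O)c(O)c1`, in a functional assay on WiDr cells (Homo sapiens) for cytotoxicity, read by sulforhodamine B assay, with a stated time of 96 h (a higher number here means a weaker inhibitor, a lower number a stronger inhibitor), gives 136000 nM.
Compound 2, `CCCCCCNC(=O)/C=C/c1ccc(O)c(O)c1`, in this assay gives 30800 nM.

Compound 2 has the lower of the two numbers, and its gap to compound 1 lies beyond the usual scatter of repeated measurements. Compound 1 and compound 2 differ in more than one place, so the pair says nothing about any single change on its own.

The next compound, compound 3, `CCCCCCNC(=O)/C=C/c1cc(O)c(O)c(O)c1`, differs from compound 2 in one place: hydroxy in place of hydrogen on an aromatic carbon. Going by the values given here, no pair of measured compounds shows this change by itself, so there is no direct guide to its effect. Compound 1 carries the same three hydroxy groups as compound 3, but it also lacks the hexyl amide, so its number cannot be split between the two changes. With only this to go on, the expectation in this assay is for a step no larger than the scatter, in either direction. The estimate for compound 3 is 30000 nM, within 10000 nM to 90000 nM. The expected step is a 1.0-fold lower number from compound 2 to compound 3 (0.01 log units; within the scatter).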

Compound 3, half-maximal inhibitory concentration: 31700 nM
Estimate against measurement, compound 3: 1.1-fold (0.02 log units) below; the measured number falls inside the stated range.
By their numbers in this assay, from the lowest: compounds 2 and 3 (each within the scatter of the next); then compound 1.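

Going by these compounds alone, this is the first comparison that isolates one added hydroxy group, ortho to a hydroxy group and meta to a large group, and in this assay it gives a 1.0-fold higher number from compound 2 to compound 3 (0.01 log units; within the scatter), so the added hydroxy group makes no measurable difference on the hexyl amide. Compound 3 carries the same hydroxy groups as compound 1, yet compound 1 gives 136000 nM while compound 3 gives 31700 nM, so this hydroxy group alone does not account for the gap between compound 1 and compound 2. No measurement here explains why the number holds steady across this change.

Within the data shown here, still open is whether the same hydroxy change would also leave the number in place on a carboxylic acid such as that of compound 1, since the only step available was read on the hexyl amide. It is also unknown how a methoxy group or a fluorine atom at this position, or a longer chain in place of hexyl, would read in this assay.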